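A Small Aryl Swap Tried on a Second Core

The source may hold more compounds than are shown below. What is called first, only, known or untested is meant among the compounds shown, and "the series" means these compounds.

Measured compounds:
compound 1, `Cc1cc(=O)n(-c2ccccc2OC(F)(F)F)nc1C(=O)Nc1ccc(Oc2ncnc3ccsc23)c(F)c1`, 15700 nM
compound 2, `Cc1cc(=O)n(-c2cccc(F)c2)nc1C(=O)Nc1ccc(Oc2ncnc3ccsc23)c(F)c1`, 7810 nM
compound 3, `Cc1cc(=O)n(-c2ccccc2OC(F)(F)F)nc1C(=O)Nc1ccc(Oc2ncnc3sccc23)cc1`, 14400 nM

These three compounds were tested in a functional assay on HepG2 cells (Homo sapiens) for cytotoxicity, read by MTT assay, with a stated time of 72 h; a higher number here means a weaker inhibitor, a lower number a stronger inhibitor. Compound 1 and compound 2 share one core and differ by a single change, (3-fluorophenyl in place of 2-(trifluoromethoxy)phenyl on an aromatic nitrogen). That change gave a 2.0-fold lower number from compound 1 to compound 2 (0.30 log units; within the scatter), a step that stays inside the scatter of repeated measurements, so it does not show a real gain on its own.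

Compound 3 carries the same 2-(trifluoromethoxy)phenyl group on a second core. How the core of compound 3 differs from the core of compound 1 is not broken down here; the two values of compound 1 and compound 3 lie within the scatter of each other.

Compound 4, `Cc1cc(=O)n(-c2cccc(F)c2)nc1C(=O)Nc1ccc(Oc2ncnc3sccc23)cc1`, is not yet measured. It differs from compound 3 by 3-fluorophenyl in place of 2-(trifluoromethoxy)phenyl on an aromatic nitrogen, the same change as from compound 1 to compound 2 at the same place. Because a 2.0-fold lower number from compound 1 to compound 2 (0.30 log units; within the scatter) was small, a similar step of a 1.9-fold lower number from compound 3 to compound 4 (0.28 log units; within the scatter) is expected. Compound 4 is estimated at 7500 nM, likely between 3500 nM and 16000 nM.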

Compound 4, half-maximal inhibitory concentration: 18500 nM
The estimate for compound 4 lay 2.5-fold (0.39 log units) below the measured number; measured number outside the range, above it.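

In this assay, placing 3-fluorophenyl where 2-(trifluoromethoxy)phenyl had been gave a 1.3-fold higher number from compound 3 to compound 4 (0.11 log units; within the scatter) on the second core, a step that cannot be told apart from the scatter of repeated measurements. The first core also gave a step inside the scatter, so this swap shows no clear effect on either core, and these data cannot show that a real gain or loss carries from one core to the other. The opposite directions of the two steps should not be read as a true difference between the cores, as the comparison shows: the same change on two cores in this assay, a 2.0-fold lower number (0.30 log units; within the scatter) from compound 1 to compound 2 and a 1.3-fold higher number (0.11 log units; within the scatter) from compound 3 to compound 4, 2.6-fold (0.41 log units) apart, within the scatter of two such steps.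

From the compounds shown here alone, whether a carboxylic acid or an amine on that aromatic ring would move the number beyond the scatter on either core remains open. Also open, going by these compounds, is whether a change with a clear effect on one core would give a matching step on the other.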